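A few compounds are considered here, and "the series" means these few. Any claim that something is new, unique, unknown or untested is made for them only; others in the source may bear on it.

Compound 1, `Oc1ccc(-c2nc3cc(C(F)(F)F)ccc3[nH]2)cc1`, gives > 100000 nM in an ADME assay on Vero cells (Chlorocebus sabaeus) for cytotoxicity; a higher number here means that more compound is tolerated, a lower number that less compound is tolerated.
Compound 2, `CC(=O)Nc1ccc(-c2nc3cc(C(F)(F)F)ccc3[nH]2)cc1`, gives 50000 nM in this assay.

The value of compound 1 in this assay is a limit of the assay, not a number. Compound 2 therefore stands as the only actual number shown; the other value is a limit, as recorded in the limit of > 100000 nM in this assay, at which 1 of the 2 values shown sits. For the measured compounds named here, the one measured step, an at least 2.0-fold lower number from compound 1 to compound 2 (0.30 log units; that floor lies within the scatter), concerns acetamido in place of hydroxy on an aromatic carbon and reaches only the floor of the scatter.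

Compound 3, `O=C(CCl)Nc1ccc(-c2nc3cc(C(F)(F)F)ccc3[nH]2)cc1`, differs from compound 2 by chloro in place of hydrogen on a saturated chain carbon bound to a carbonyl carbon. No measured step touches a saturated chain carbon bound to a carbonyl carbon, so nothing shown bears directly on this change. With no evidence either way, compound 3 is expected to land within the scatter of compound 2, a step of no change at the digits printed from compound 2 to compound 3 (within the scatter). Compound 3 is estimated at 50000 nM, with a range from 15000 nM to 100000 nM.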

Compound 3, half-maximal cytotoxic concentration: 35000 nM
Compound 3: middle estimate off by 1.4-fold (0.15 log units), on the high side, within the range that was stated.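

In this assay, chloro in place of hydrogen on a saturated chain carbon bound to a carbonyl carbon gives a 1.4-fold lower number from compound 2 to compound 3 (0.15 log units; within the scatter), so this first reading at that position shows no change that can be told from the scatter. Taken from the hydroxy compound, ((chloromethyl)carbonyl)amino in place of hydroxy on an aromatic carbon gives an at least 2.8-fold lower number from compound 1 to compound 3 (0.45 log units; beyond the scatter), which clears the scatter, whereas the acetamido step reached only its floor. That step remains a minimum, since the value of compound 1 is a limit of the assay and not a number: the limit of > 100000 nM in this assay, at which 1 of the 3 values shown sits.

The compounds shown leave open how far the number would move with a bromo, an amine or a longer chain on that same carbon. They also leave open how large the true gap from compound 1 is.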